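A few compounds are considered here, and "the series" means these few. Any claim that something is new, unique, unknown or untested is made for them only; others in the source may bear on it.

Working notes on the series. Within the data shown here, in an ADME assay for permeability, using PAMPA, at pH 5.5 (on this read-out lower numbers stand for lower permeability and higher numbers for higher permeability), compound 1 (`CCCCc1nc(=O)c(S(=O)(=O)c2ccc(-c3ccc(F)cc3)cc2)c(O)n1-c1c(OC)cccc1OC`) gives 418 nm/s, the only number available so far. Among the measured compounds shown here, for compound 2 (`CCCCc1[nH]c(=O)c(S(=O)(=O)c2ccc(-c3ccc(F)nc3)cc2)c(O)c1-c1c(OC)cccc1OC`) the entry in this assay reads "not determined" (no result reported), so compound 1 cannot yet be ranked against any other compound, and no measured pair shows how the read-out responds to a structural change.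

Compound 3 (`CCCCc1nc(=O)c(S(=O)(=O)c2ccc(C3CC3)cc2)c(O)n1-c1c(OC)cccc1OC`) keeps the core of compound 1 and differs in one place: cyclopropyl in place of 4-fluorophenyl on an aromatic carbon, para to a large group (cyclopropyl in place of 4-fluorophenyl on an aromatic carbon).

For the measured compounds named here, with no measured step to scale from, the expectation rests on compound 1 at 418 nm/s and on the structural change alone. Going by these compounds, no shift beyond the usual scatter is expected, and the direction remains open, with only a slight lean towards a higher number. The estimated step is a 1.2-fold higher number from compound 1 to compound 3 (0.08 log units; within the scatter). For compound 3 the expected value is 500 nm/s, with an estimated range of 180 nm/s to 1200 nm/s, kept wide since the estimate rests on a single measurement.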

Compound 3, apparent permeability: 615 nm/s
The estimate for compound 3 lay 1.2-fold (0.09 log units) below the measured number, and the stated range covers the measured number.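

Among these compounds, this is the first measured step: in this assay, cyclopropyl in place of 4-fluorophenyl on an aromatic carbon, para to a large group, gives a 1.5-fold higher number from compound 1 to compound 3 (0.17 log units; within the scatter). At this place, then, a group of 7 heavy atoms with a six-membered aromatic ring of carbon only gives way to a group of 3 heavy atoms with a three-membered non-aromatic ring, and the read-out does not separate the two compounds. No measurement at hand accounts for the two numbers, so the step stands as an observation without an explanation.

Both groups count 0 hydrogen-bond donors, 0 hydrogen-bond acceptors and no net charge, so the step says nothing about how an amine or a carboxylic acid at this place would read in this assay. Going by these compounds, whether a longer chain there would also stay within the scatter remains open, and this single step sets no scale for changes elsewhere on the core of compound 1.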